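Trimming Tert-Butyl to Methyl on a Shared Core

This account rests on a few compounds, and the source may have more. Where it says the series, first, only, none or still open, it means among the compounds named here.

Three compounds sharing one core were tested in an assay on FRT-Jurkat cells for inhibition of nuclear factor NF-kappa-B complex (Homo sapiens), read by flow cytometry, with a stated time of 24 h, tested at 10 uM; a lower number here means less inhibition, a higher number more inhibition at the concentration tested (going by the name of the read-out). Compound 1 `CC(C)(C)c1ccc(Nc2cccc3c2C(=O)N(C2CCC(=O)NC2=O)C3=O)cc1` gives 36%, the highest of the three numbers. Compound 2 `O=C1CCC(N2C(=O)c3ccc(Nc4ccc(O)cc4)cc3C2=O)C(=O)N1` gives 4%, and compound 3 `CCOC(=O)c1ccc(Nc2ccc3c(c2)C(=O)N(C2CCC(=O)NC2=O)C3=O)cc1` gives 5%; both sit far below compound 1, beyond the scatter. Among the compounds with values here, the only step between measured compounds, a number 1 percentage points higher from compound 2 to compound 3 (within the scatter), shows a change that barely moved the number, but it concerns a different part of the molecule. Compound 4 `Cc1ccc(Nc2cccc3c2C(=O)N(C2CCC(=O)NC2=O)C3=O)cc1` differs from compound 1 by methyl in place of tert-butyl on an aromatic carbon. Within the data shown here, no measured step addresses this change, so the expectation rests on compound 1 alone and is uncertain. A step of a number 14 percentage points lower from compound 1 to compound 4 (beyond the scatter) is expected, downward and of moderate size. Compound 4 is therefore estimated at 22%, with a range from 5% to 40%.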

Compound 4, a percentage reported as inhibition, at one concentration (the size of the read-out at that concentration, not a potency): 9%
Compound 4: middle estimate off by 13 percentage points, on the high side; the measured number falls inside the stated range.
By their numbers in this assay, from the lowest: compounds 2, 3 and 4 (each within the scatter of the next); then compound 1.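

In this assay, methyl in place of tert-butyl on this aromatic carbon gives a number 27 percentage points lower from compound 1 to compound 4 (beyond the scatter) and so marks the group at this place as one that matters for the read-out, unlike the earlier step, which concerned a different part of the molecule and stayed within the scatter. No measured evidence here explains the drop. What the compounds shown leave open is how an ethyl, an isopropyl or an amine on the same carbon would read, and so whether the number climbs gradually from methyl to tert-butyl or appears only with tert-butyl itself.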